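Smaller Saturated Ring Within the Same Fused Group

This account rests on a few compounds, and the source may have more. Where it says the series, first, only, none or still open, it means among the compounds named here.

Of the compounds shown here, three sharing one core have been tested in a functional assay on HCT-116 cells (Homo sapiens) for inhibition, read by MTT assay, with a stated time of 72 h, tested at 20 uM; a lower number here means less inhibition, a higher number more inhibition at the concentration tested (going by the name of the read-out). Compound 1 `c1cc(N2CCCCC2)nc(Nc2ccc(Oc3ncnc4sccc34)cc2)n1` gives 66.3%. Compound 2 `c1cc(N2CCCC2)nc(Nc2ccc(Oc3ncnc4sccc34)cc2)n1`, carrying pyrrolidin-1-yl in place of piperidin-1-yl, gives 54.4%, a change of a number 11.9 percentage points lower from compound 1 to compound 2 (beyond the scatter). Compound 3 `c1ccc2c(c1)CCN(c1ccnc(Nc3ccc(Oc4ncnc5sccc45)cc3)n1)C2` gives 18.1%, the lowest of the three: the steps of a number 48.2 percentage points lower from compound 1 to compound 3 (beyond the scatter) and a number 36.3 percentage points lower from compound 2 to compound 3 (beyond the scatter) are both large and beyond the scatter.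

Compound 4 `c1ccc2c(c1)CCN2c1ccnc(Nc2ccc(Oc3ncnc4sccc34)cc2)n1` has not been measured. It differs from compound 3 by 2,3-dihydro-1H-indol-1-yl in place of 1,2,3,4-tetrahydroisoquinolin-2-yl on an aromatic carbon.

Going by the values given here, both large drops came with 1,2,3,4-tetrahydroisoquinolin-2-yl entering; the one step that only changed a saturated ring from six-membered to five-membered, a number 11.9 percentage points lower from compound 1 to compound 2 (beyond the scatter), was modest. Compound 4 keeps the six-membered aromatic ring of carbon only and shrinks the non-aromatic ring, so only a small shift from compound 3 is expected. Compound 4 is therefore expected to give 24%, between 6% and 48%. The expected step is a number 5.9 percentage points higher from compound 3 to compound 4 (within the scatter), likely within the scatter.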

Compound 4, a percentage reported as inhibition, at one concentration (the size of the read-out at that concentration, not a potency): -0.62%
For compound 4 the middle estimate is 24.6 percentage points above the measured one; the whole stated range lies above it.
By their numbers in this assay, from the lowest: compound 4; then compound 3; then compound 2; then compound 1.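

The same ring shrinkage, from six-membered to five-membered, now lowers the number in both pairs that allow the comparison: a number 11.9 percentage points lower from compound 1 to compound 2 (beyond the scatter) with the saturated rings alone, and a number 18.7 percentage points lower from compound 3 to compound 4 (beyond the scatter) with the saturated ring fused to a six-membered aromatic ring of carbon only. At this position, then, the size of the non-aromatic ring still matters once the aromatic ring is present, and the 2,3-dihydro-1H-indol-1-yl group leaves compound 4 far behind the unfused groups, with a number 55 percentage points lower from compound 2 to compound 4 (beyond the scatter) and a number 66.9 percentage points lower from compound 1 to compound 4 (beyond the scatter) in this assay. No measurement at hand explains these drops.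

As far as these compounds go, whether a morpholine ring, with oxygen in the saturated ring, would keep the number near that of compound 1 remains open. So does the effect of an open-chain amine such as diethylamino at this carbon.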